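A Smaller Thiophene Ring on the Shared Core

This account rests on a few compounds, and the source may have more. Where it says the series, first, only, none or still open, it means among the compounds named here.

Compound 3 `Cc1ccc(-c2nc(CNc3ccc(C(=O)NO)cc3)n(-c3ccccc3)n2)s1` stands highest of the three compounds measured in an assay on Sf9 cells for inhibition of protein deacetylase HDAC6 (Homo sapiens), read by fluorescence, with a stated time of 40 min, tested at 100 nM (on this read-out higher numbers stand for more inhibition at the one concentration tested (going by the name of the read-out) and lower numbers for less inhibition), where compound 3 gives 79.7%. Its nearest neighbour is compound 1 `O=C(NO)c1ccc(NCc2nc(-c3ccc(Br)cc3)nn2-c2ccccc2)cc1`, which gives 54.7%, and the furthest is compound 2 `O=C(NO)c1ccc(NCc2nc(-c3ccc(Cl)c(Cl)c3)nn2-c2ccccc2)cc1`, which gives 34.5%. The steps among them are a number 25 percentage points higher from compound 1 to compound 3 (beyond the scatter), a number 45.2 percentage points higher from compound 2 to compound 3 (beyond the scatter) and a number 20.2 percentage points lower from compound 1 to compound 2 (beyond the scatter), so all three changes at this aromatic carbon lie beyond the scatter.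

Compound 4 `O=C(NO)c1ccc(NCc2nc(-c3ccsc3)nn2-c2ccccc2)cc1` differs from compound 3 in one place: thiophen-3-yl in place of 5-methylthiophen-2-yl on an aromatic carbon.

Every measured step swaps the whole group at this carbon, and none exchanges one thiophene for another, so the measured steps bear on compound 4 only by showing that the group at this position moves the read-out by modest to large amounts. The change to compound 4 is smaller than those measured, removing the methyl and shifting the attachment point of the same ring type. A modest loss in this assay is therefore expected rather than a large one. Compound 4 is expected to give 62%, within a range from 42% to 80%. The expected step is a number 17.7 percentage points lower from compound 3 to compound 4 (beyond the scatter).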

Compound 4, a percentage reported as inhibition, at one concentration (the size of the read-out at that concentration, not a potency): 53.4%
Compound 4: middle estimate off by 8.6 percentage points, on the high side, and the stated range covers the measured number.
By their numbers in this assay, from the lowest: compound 2; then compounds 4 and 1 (each within the scatter of the next); then compound 3.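

Among the compounds shown here, the first exchange of one thiophene for another at this carbon shows that the read-out in this assay depends on more than the ring type, with a number 26.3 percentage points lower from compound 3 to compound 4 (beyond the scatter) for this change alone. The high number of compound 3 therefore cannot be credited to a thiophene as such, and it belongs to the 5-methylthiophen-2-yl group as a whole. The thiophen-3-yl group also gives a number 1.3 percentage points lower from compound 1 to compound 4 (within the scatter) and a number 18.9 percentage points higher from compound 2 to compound 4 (beyond the scatter) on the other two comparisons, which places compound 4 level with the 4-bromophenyl compound and clear of the 3,4-dichlorophenyl compound, so a five-membered ring at this carbon is no guarantee of a gain over a phenyl group.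

The step from compound 3 to compound 4 joins two changes, the loss of the methyl and the shift of the attachment point, and the compounds shown cannot separate them, nor do they tell how the plain thiophen-2-yl group or a thiophene carrying an amine or a carboxylic acid would read. Nothing available here accounts for any of these steps, so their cause stays unexplained.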